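A Smaller Side Chain on the Shared Core

The source may report more compounds than this note shows. Statements on the series, on what has been measured and on what is new or still open speak of the compounds shown alone.

Of the compounds shown here, two have so far been measured in an assay on cells with melanin-concentrating hormone receptor 1 (Homo sapiens) as the target, read by radioligand binding; on this read-out higher numbers stand for weaker inhibition and lower numbers for stronger inhibition. Compound 1 `CCOCC(C)Oc1cccc2ccc(N)nc12` gives 1070 nM, the higher of the two numbers. Compound 2 `Nc1ccc2cccc(OCC3CC4CCC3C4)c2n1` gives 137 nM, a lower number that lies beyond the scatter. Compound 3 `CSCCOc1cccc2ccc(N)nc12` has not yet been measured; it differs from compound 1 in a group of 4 heavy atoms (3 carbon, 1 sulfur; no ring) in place of a group of 6 heavy atoms (5 carbon, 1 oxygen; no ring), on an oxygen on an aromatic ring. Among the measured compounds shown here, no step between measured compounds speaks to this change, so the step from compound 1 to compound 3 is expected to be small, a 1.2-fold lower number from compound 1 to compound 3 (0.08 log units; within the scatter), with no clear direction. Compound 3 is therefore expected to give 900 nM, within 300 nM to 2700 nM.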

Compound 3, half-maximal inhibitory concentration: > 2000 nM
Compound 3 ended at the assay's limit; the forecaster's own chance of this, stated with the estimate: 5%; at least 2.2-fold (0.34 log units) between middle value and limit.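

In this assay, compound 3 gives > 2000 nM, which is a limit of the assay and not a number. With 2-(methylsulfanyl)ethyl on this oxygen, the change reads as an at least 1.8-fold higher number from compound 1 to compound 3 (0.27 log units; that floor lies within the scatter); it shows no gain in inhibition, but only a floor is known and the true size of the step cannot be read. The read-out stops at this point: the limit of > 2000 nM in this assay, at which 1 of the 3 values shown sits.

Compound 3 alters the chain's size and brings in sulfur together, and these two changes cannot be told apart here. A 2-methoxyethyl chain on the same oxygen would separate them.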